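This account rests on a few compounds, and the source may have more. Where it says the series, first, only, none or still open, it means among the compounds named here.

Measured so far:
- compound 1 `Cn1nnnc1SCC(=O)N/N=c1/scc(-c2ccccc2)n1-c1ccccc1` gives 26.8%
- compound 2 `O=C(CSc1ncccn1)N/N=c1/scc(-c2ccc(Br)cc2)n1-c1ccccc1` gives 63.2%

Both numbers come from a functional assay on C6 cells (Rattus norvegicus) for cytotoxicity, read by MTT assay, with a stated time of 24 h, tested at 200 ug/mL; on this read-out higher numbers stand for a weaker effect at the one concentration tested and lower numbers for a stronger effect. Of the two compounds, compound 2 stands highest, and the gap to compound 1 is beyond the scatter, so compound 2 is the weaker of the pair on this read-out, leaving more of the cells alive at the single concentration tested.

Compound 3 `COc1ccc(-c2cs/c(=N/NC(=O)CSc3ncccn3)n2-c2ccccc2)cc1` has not been measured. It is compound 2 with one change: methoxy in place of bromo on an aromatic carbon. Within the data shown here, no measured pair of compounds shows this same change, so there is nothing in the data to tell how large a step it brings in this assay or in which direction. Among the measured compounds shown here, the only guidance is that the two measured compounds differ in several places at once, and their values lie far apart, which shows that the read-out can move a long way between related structures.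

Compound 3 is therefore expected to stay near compound 2, with a step of a number 7.2 percentage points lower from compound 2 to compound 3 (within the scatter) as the estimate. The value for compound 3 is estimated at 56%, within a range from 30% to 82%.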

Compound 3, a percentage reported as activity, at one concentration (the size of the read-out at that concentration, not a potency): 37.6%
Estimate against measurement, compound 3: 18.4 percentage points above; the range from low to high includes it.
By their numbers in this assay, from the lowest: compound 1; then compound 3; then compound 2.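

In this assay, replacing 4-bromophenyl with 4-methoxyphenyl gives a step of a number 25.6 percentage points lower from compound 2 to compound 3 (beyond the scatter) and thus a stronger effect at the one concentration tested. The earlier comparison involved compounds that differ in several places at once, whereas this pair isolates one aromatic carbon and shows that a change there is enough on its own to shift the read-out clearly. The information available gives no measured property that accounts for this step, and the reason for it remains unknown.

Going by these compounds, with only bromo and methoxy to compare at this position, a single step cannot establish a trend, and it remains open whether an amine, a carboxylic acid or a nitrile in the same place would push the read-out further in this direction, reverse it or leave it unchanged. It is also unclear whether the same exchange would bring a step of similar size and direction when the rest of the molecule differs, as it does in compound 1, which carries neither bromo nor methoxy on its phenyl ring.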